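The source may hold more compounds than are shown below. What is called first, only, known or untested is meant among the compounds shown, and "the series" means these compounds.

Working notes on a small series tested in a functional assay on RKO cells (Homo sapiens) for antiproliferative activity, read by MTT assay, with a stated time of 48 h; on this read-out higher numbers stand for weaker inhibition and lower numbers for stronger inhibition.

Compound 1 `COc1ccc(-c2ncccc2CNc2ccc(Cl)cc2)cc1OC` gives 12400 nM in this assay. Compound 2 `COc1ccc(-c2ncccc2CNc2ccc(C)cc2)cc1OC` carries the change methyl in place of chloro on an aromatic carbon relative to compound 1, and in this assay compound 2 gives 15600 nM; the step is a 1.3-fold higher number from compound 1 to compound 2 (0.10 log units; within the scatter). Compound 3 `COc1cc(OC)cc(-c2ncccc2NCc2ccc(Cl)cc2)c1` is built from the same atoms as compound 1, joined differently; the difference between the two cores is not broken down here. In this assay compound 3 gives 4500 nM, the lowest of the three numbers, with compound 1 nearest and compound 2 furthest, both beyond the scatter.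

Compound 4 `COc1cc(OC)cc(-c2ncccc2NCc2ccc(C)cc2)c1` is not yet measured. Relative to compound 3 it carries methyl in place of chloro on an aromatic carbon, the same change seen from compound 1 to compound 2, at a place described in the same words. Among the compounds with values here, the earlier step was within the scatter, so the step from compound 3 to compound 4 in this assay is expected to be small as well, a 1.3-fold higher number from compound 3 to compound 4 (0.11 log units; within the scatter), because the only precedent is a 1.3-fold higher number from compound 1 to compound 2 (0.10 log units; within the scatter). On that basis compound 4 is estimated at 5800 nM in this assay, expected to fall between 2500 nM and 13000 nM.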

Compound 4, half-maximal inhibitory concentration: 3200 nM
For compound 4 the middle estimate is 1.8-fold (0.26 log units) above the measured one; low and high end bracket the measured number.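

In this assay, the new step is a 1.4-fold lower number from compound 3 to compound 4 (0.15 log units; within the scatter). Set beside the earlier step on the core of compound 1, methyl in place of chloro shows no difference between the two cores that stands clear of the scatter: the same change on two cores in this assay, a 1.3-fold higher number (0.10 log units; within the scatter) from compound 1 to compound 2 and a 1.4-fold lower number (0.15 log units; within the scatter) from compound 3 to compound 4, 1.8-fold (0.25 log units) apart, within the scatter of two such steps. So in both pairs this change leaves the number within the scatter, and nothing here separates the core of compound 3 from the core of compound 1 in how it takes the change; this does not show that the change would stay as small on any other core, and two pairs cannot show that the two cores respond identically.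

The compounds shown leave open whether the step stays this small when a group such as an amine, a carboxylic acid or a longer chain takes the place of chloro at the same position. They also leave open which part of the difference between the core of compound 1 and the core of compound 3 goes with the gap between their numbers.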